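Benzyl ether variation in an amine oxidase A series

The compounds below may be only part of what the source reports. "The series", "measured", "known", "first", "only" and "open" are said of these compounds alone.

Measured compounds in this assay:
compound 1 `N#CCCN1N=C(c2ccc(OCc3ccccc3)cc2)OCC1=O`: 160000 nM
compound 2 `COc1cccc(COc2ccc(C3=NN(CCC#N)C(=O)CO3)cc2)c1`: 32000 nM
compound 3 `Cc1ccc(COc2ccc(C3=NN(CCC#N)C(=O)CO3)cc2)cc1`: 250000 nM

In an assay for inhibition of Amine oxidase [flavin-containing] A (Rattus norvegicus) (a higher number here means a weaker inhibitor, a lower number a stronger inhibitor), compound 3 gives the highest number of the three, but its distance to compound 1 is within the scatter, so no order between those two can be stated; compound 2 sits clearly apart, as a 7.8-fold higher number from compound 2 to compound 3 (0.89 log units; beyond the scatter) shows. Compound 4 `N#CCCN1N=C(c2ccc(OCc3cccc(Cl)c3)cc2)OCC1=O` differs from compound 3 by 3-chlorophenyl in place of 4-methylphenyl on a saturated chain carbon bound to an oxygen on an aromatic ring. For the measured compounds named here, two measured steps bear on this. a 1.6-fold higher number from compound 1 to compound 3 (0.19 log units; within the scatter) shows that a methyl on the aromatic carbon gives no change beyond the scatter, while a 5.0-fold lower number from compound 1 to compound 2 (0.70 log units; beyond the scatter) shows a modest fall for methoxy on an aromatic carbon. Going by the values given here, the incoming 3-chlorophenyl, like 3-methoxyphenyl, is a singly substituted ring, but no chloro analogue has been measured, so the transfer is uncertain. A modest fall is therefore expected in this assay, a 3.6-fold lower number from compound 3 to compound 4 (0.55 log units; beyond the scatter), short of the gain seen with compound 2. Compound 4 is estimated at 70000 nM, with a range of 18000 nM to 280000 nM.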

Compound 4, half-maximal inhibitory concentration: 13000 nM
Compound 4: the middle estimate sits 5.4-fold (0.73 log units) above what was measured; the whole stated range lies above it.
By their numbers in this assay, from the lowest: compound 4; then compound 2; then compounds 1 and 3 (each within the scatter of the next).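

In this assay, for the compounds shown here, the benzyl ether ring proves more sensitive than the earlier compounds showed, with a 19-fold lower number from compound 3 to compound 4 (1.28 log units; beyond the scatter) when 3-chlorobenzyl replaces 4-methylbenzyl. The chloro group also outdoes both earlier comparators, with a 12-fold lower number from compound 1 to compound 4 (1.09 log units; beyond the scatter) for chloro in place of hydrogen and a 2.5-fold lower number from compound 2 to compound 4 (0.39 log units; beyond the scatter) for chloro in place of methoxy, which makes compound 4 the strongest inhibitor of the four. Nothing measured here accounts for this gain.

From the compounds shown here alone, compounds 3 and 4 differ in both the ring substituent and where it stands, so the share of each in the step remains open. A 3-methylphenyl or 4-chlorophenyl analogue would separate the two, and a 3-bromophenyl or 3-trifluoromethylphenyl analogue would show whether the gain extends beyond chloro.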